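This account rests on a few compounds, and the source may have more. Where it says the series, first, only, none or still open, it means among the compounds named here.

Working notes on the series. Compound 1 `C[C@]1(CN2CCc3nc(-c4ccc(Cl)cc4)ccc3C2)Cn2cc([N+](=O)[O-])nc2O1`, compound 2 `C[C@]1(CN2CCc3nc(-c4ccc(Cl)cc4F)ccc3C2)Cn2cc([N+](=O)[O-])nc2O1` and compound 3 `C[C@]1(CN2CCc3nc(-c4cc(F)cc(Cl)c4)ccc3C2)Cn2cc([N+](=O)[O-])nc2O1` share one core and differ only in the substituted phenyl carried on it. In an ADME assay on Vero cells (Chlorocebus sabaeus) for cytotoxicity, read by MTT assay, with a stated time of 72 h (a higher number here means that more compound is tolerated, a lower number that less compound is tolerated), compound 1 gives "not determined" (no result reported). In this assay compound 2 reaches a limit of the assay, > 32 ug/mL. In this assay compound 3 likewise reaches a limit of the assay, > 32 ug/mL. The step that the two limits leave unreadable from compound 2 to compound 3 therefore cannot be read. Among the compounds with values here, what the numbers show is summarised by the limit of > 32 ug/mL in this assay, at which 2 of the 3 values shown sit; compound 3 thus stands at that limit, and no compound carries a measured number in this assay against which it could be placed.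

Compound 4 `C[C@]1(CN2CCc3nc(-c4cc(F)c(F)c(F)c4)ccc3C2)Cn2cc([N+](=O)[O-])nc2O1` differs from compound 3 by 3,4,5-trifluorophenyl in place of 3-chloro-5-fluorophenyl on an aromatic carbon. Within the data shown here, the only measured step that bears on this change is the one from compound 2 to compound 3, and it is unreadable, so the series supplies no step of any readable size in this assay for a change of the substituents on the phenyl. The expectation for compound 4 in this assay is therefore a step of about a number no higher from compound 3 to compound 4 (the limit leaves the size open), that is none beyond the scatter, with the result most likely again reported as a limit. Compound 4 is estimated at 32 ug/mL in this assay, in the range 16 ug/mL to 64 ug/mL.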

Compound 4, half-maximal cytotoxic concentration: > 32 ug/mL
Compound 4 gave a limit, no number; the forecaster's own chance of this, stated with the estimate: 80%; the middle value lies on the limit itself.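

In this assay compound 4 gives > 32 ug/mL, a limit of the assay and not a number. The steps to compound 4 from compound 2 and from compound 3 therefore cannot be read. The compounds shown leave open whether changing the substituted phenyl shifts the result at all, as the series rests on one limit: the limit of > 32 ug/mL in this assay, at which 3 of the 4 values shown sit.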